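Methyl on the core of compound 2: working notes

The compounds below may be only part of what the source reports. "The series", "measured", "known", "first", "only" and "open" are said of these compounds alone.

Measured in a functional assay on U-251 cells (Homo sapiens) for antiproliferative activity; a higher number here means a weaker inhibitor of growth, a lower number a stronger inhibitor of growth:
- compound 1 `Cc1cccc(-c2cc(O)c3ccc(C)nc3n2)c1`: 200 nM
- compound 2 `Oc1cc(-c2ccc3ccccc3c2)nc2ncccc12`: 4370 nM

Of these two compounds, compound 2 gives the higher number, so it is the weaker inhibitor of growth, and its gap to compound 1 lies beyond the scatter.

The next compound is compound 3 `Cc1ccnc2nc(-c3ccc4ccccc4c3)cc(O)c12`. It carries methyl in place of hydrogen on an aromatic carbon of the six-membered aromatic ring with 1 nitrogen, opposite the ring nitrogen (methyl in place of hydrogen on an aromatic carbon).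

Among the measured compounds shown here, no measured pair shows this change alone, so the data offer no direct guide. A modest step toward a lower number is expected in this assay, though it may not clear the scatter. The expected change is a 2.0-fold lower number from compound 2 to compound 3 (0.30 log units; within the scatter). The estimate for compound 3 is 2200 nM, with an expected range of 600 nM to 7000 nM.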

Compound 3, concentration for 50% growth inhibition: 646 nM
Compound 3: middle estimate off by 3.4-fold (0.53 log units), on the high side; measured number inside the range.
By their numbers in this assay, from the lowest: compound 1; then compound 3; then compound 2.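

In this assay, among the compounds shown here, methyl in place of hydrogen on an aromatic carbon, opposite the ring nitrogen, gives a 6.8-fold lower number from compound 2 to compound 3 (0.83 log units; beyond the scatter) and is the only single-place change so far. This step lies beyond the scatter, so this carbon does not tolerate substitution silently: one added methyl, with the rest of compound 2 unchanged, is enough to shift the number toward stronger inhibition of growth. No measurement at hand explains the size or direction of this step.

The compounds shown leave open whether the shift is particular to methyl or also appears with a longer chain such as ethyl, with methoxy or with an amine on the same carbon. On these data alone, it also remains open whether the same methyl change gives a comparable step when the aromatic group of compound 1 replaces that of compound 2.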